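From 4-cyanophenyl to 3-cyanophenyl in compound 2

The source may report more compounds than this note shows. Statements on the series, on what has been measured and on what is new or still open speak of the compounds shown alone.

Measured in a functional assay on U-373MG ATCC cells (Homo sapiens) for inhibition, read by MTT assay, with a stated time of 72 h; on this read-out lower numbers stand for stronger inhibition and higher numbers for weaker inhibition:
Compound 1 `CC1(C)CC(NC(=S)Nc2ccc(C#N)cc2)c2cc(F)ccc2O1`: 11000 nM
Compound 2 `CC1(C)CC(NC(=S)Nc2ccc(C#N)cc2)c2cc(Cl)ccc2O1`: 10000 nM

Compound 2 stands within the scatter of compound 1, so neither can be ranked above the other. Compound 3 `CC1(C)CC(NC(=S)Nc2cccc(C#N)c2)c2cc(Cl)ccc2O1` carries 3-cyanophenyl in place of 4-cyanophenyl on an amide-type nitrogen. Among the measured compounds shown here, the only measured step, a 1.1-fold lower number from compound 1 to compound 2 (0.04 log units; within the scatter), is chloro in place of fluoro on an aromatic carbon and leaves the cyanophenyl group untouched. For the measured compounds named here, no measured pair tests the new change, so no step beyond the scatter is expected in this assay, and no direction can be favoured. The expected step is no change at the digits printed from compound 2 to compound 3 (within the scatter). Compound 3 is estimated at 10000 nM, with an expected range of 4000 nM to 25000 nM.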

Compound 3, half-maximal inhibitory concentration: 7000 nM
Estimate against measurement, compound 3: 1.4-fold (0.15 log units) above; measured number inside the range.
By their numbers in this assay, from the lowest: compounds 3, 2 and 1 (each within the scatter of the next).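

In this assay the exchange of 4-cyanophenyl for 3-cyanophenyl on an amide-type nitrogen gives a 1.4-fold lower number from compound 2 to compound 3 (0.15 log units; within the scatter) and stays within the scatter, so the two cyanophenyl groups cannot be ranked at this place. The earlier pair varied only a halogen on an aromatic carbon, whereas this pair shows that the number tolerates this change in the group on the nitrogen. No evidence is available that bears on this result. As far as these compounds go, what remains open is whether a group of another kind on that nitrogen, such as a pyridine ring or a benzyl group, would give a step beyond the scatter.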